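The compounds below may be only part of what the source reports. "The series", "measured", "known", "first", "only" and "open" are said of these compounds alone.

Compound 1 `COc1ccc(-c2[nH]c3ccccc3c2/C=C(\C#N)S(=O)(=O)c2ccccc2)cc1` gives 300 nM in a functional assay on CCRF-SB cells (Homo sapiens) for cytotoxicity, read by MTT assay, with a stated time of 96 h; on this read-out higher numbers stand for an effect only at larger amounts of compound and lower numbers for an effect already at smaller amounts. Compound 2 `N#C/C(=C\c1c(-c2ccccc2)[nH]c2ccccc12)C(=O)c1cccs1` gives 600 nM in this assay.

Of the two numbers shown, compound 2 holds the higher one, but its gap to compound 1 lies within the usual scatter of repeated measurements, so the two compounds cannot be told apart on this evidence.

Compound 3 `COCCOC(=O)/C(C#N)=C/c1c(-c2ccccc2)[nH]c2ccccc12` differs from compound 2 in one place: 2-methoxyethoxy in place of thiophen-2-yl on a carbonyl carbon. Among the compounds with values here, no pair of measured compounds shows a change of this kind, so the size of the step can only be expected, not read off. A modest rise in the number is expected for compound 3, a step of a 2.0-fold higher number from compound 2 to compound 3 (0.30 log units; within the scatter). Compound 3 is therefore estimated at 1200 nM in this assay, with a plausible range from 400 nM to 4000 nM.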

Compound 3, half-maximal effective concentration: 2200 nM
The estimate for compound 3 lay 1.8-fold (0.26 log units) below the measured number; the measured number falls inside the stated range.
By their numbers in this assay, from the lowest: compounds 1 and 2 (each within the scatter of the next); then compound 3.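

Putting 2-methoxyethoxy in place of thiophen-2-yl on a carbonyl carbon gives a 3.7-fold higher number from compound 2 to compound 3 (0.56 log units; beyond the scatter) in this assay. Within the data shown here, this is the first step here that clears the scatter, so the group on this carbonyl carbon does affect the number, and in this pair the open chain needs more compound than the ring. Nothing measured here gives a reason for this step.

A single pair cannot separate losing the ring from gaining the chain. A plain ethoxy or a furan-2-yl group on the same carbonyl carbon would help to tell these apart.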